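Chloro in place of methoxy on the aryl of compound 2

The source may report more compounds than this note shows. Statements on the series, on what has been measured and on what is new or still open speak of the compounds shown alone.

In a functional assay on cells for antagonist activity at Glucagon receptor (Homo sapiens), read by cAMP accumulation (a higher number here means a weaker inhibitor, a lower number a stronger inhibitor), compound 2 `CCCC(Oc1cnn(-c2ccc(OC)cc2)c1)c1ccc(C(=O)NCCC(=O)O)cc1` reaches only a limit, > 21300 nM. Compound 1 `CCCC(Oc1cnn(-c2cccc(Cl)c2)c1)c1ccc(C(=O)NCCC(=O)O)cc1` gives 16900 nM in this assay, and compound 3 `CCCc1c(C(C)C)cc(C(C)C)c(C(C)O)c1-c1ccc(F)cc1` gives 78 nM. Compound 2 therefore stands at the limit of > 21300 nM in this assay, at which 1 of the 3 values shown sits. Among the compounds with values here, the one measured step that touches this aryl, an at least 1.2-fold higher number from compound 1 to compound 2 (0.10 log units; that floor lies within the scatter), is a change that stays within the scatter. Compound 4 `CCCC(Oc1cnn(-c2ccc(Cl)cc2)c1)c1ccc(C(=O)NCCC(=O)O)cc1` differs from compound 2 by chloro in place of methoxy on an aromatic carbon. Within the data shown here, only that single step speaks to this change, and it is small, so a step of an at least 1.0-fold lower number from compound 2 to compound 4 (0.02 log units; that floor lies within the scatter) is expected, with no movement beyond the scatter. Compound 4 is accordingly estimated at 20000 nM, with a range from 8000 nM to 60000 nM, and a fair chance that this assay again returns only a limit.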

Compound 4, antagonist equilibrium constant: > 7520 nM
Compound 4: no number, only a limit (the forecaster's own chance of this, stated with the estimate: 45%); the middle value is on the limit's open side.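

In this assay compound 4 returns only a limit, > 7520 nM. Compound 2 is also a limit, > 21300 nM. Within the data shown here, no step from compound 2 or compound 1 to compound 4 can be read. From the compounds shown here alone, whether chloro in place of methoxy moves the antagonist constant at all stays open.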